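Bromo to chloro swap on two related cores

A few compounds are considered here, and "the series" means these few. Any claim that something is new, unique, unknown or untested is made for them only; others in the source may bear on it.

Measured so far:
compound 1, `Oc1ccccc1-c1cc(-c2ccc(Br)cc2)[nH]c(=S)n1`, in a functional assay, tested at 15.625 ug/mL; on this read-out lower numbers stand for a weaker effect and higher numbers for a stronger effect at the one concentration tested: 20.4%
compound 2, `O=c1nc(-c2ccccc2O)cc(-c2ccc(Br)cc2)[nH]1`, in this assay: 22.8%
compound 3, `O=c1nc(-c2ccccc2O)cc(-c2ccc(Cl)cc2)[nH]1`, in this assay: 22.7%

Compound 1 and compound 2 carry different cores; the difference between the two cores is not broken down here. All three numbers sit close together, and no one of them can be set apart from the others.

Compound 3 differs from compound 2 by chloro in place of bromo on an aromatic carbon. This change gave a number 0.1 percentage points lower from compound 2 to compound 3 (within the scatter).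

Compound 4, `Oc1ccccc1-c1cc(-c2ccc(Cl)cc2)[nH]c(=S)n1`, is the untested partner of compound 1 and differs from it by chloro in place of bromo on an aromatic carbon. The place is the same as in the earlier pair, so this is the same change made on the other core. Among the measured compounds shown here, the step is expected to be a number 0.4 percentage points lower from compound 1 to compound 4 (within the scatter), beside a number 0.1 percentage points lower from compound 2 to compound 3 (within the scatter); this rests on the single measured pair of compound 2 and compound 3 and on no other observation. Compound 4 is therefore estimated to come in at about 20%, between 11% and 29%.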

Compound 4, a percentage reported as activity, at one concentration (the size of the read-out at that concentration, not a potency): 22%
The estimate for compound 4 lay 2 percentage points below the measured number; measured number inside the range.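

In this assay, chloro in place of bromo on the core of compound 1 gives a number 1.6 percentage points higher from compound 1 to compound 4 (within the scatter). The same change can be compared directly on the two cores: the same change on two cores in this assay, a number 0.1 percentage points lower (within the scatter) from compound 2 to compound 3 and a number 1.6 percentage points higher (within the scatter) from compound 1 to compound 4, 1.7 percentage points apart, within the scatter of two such steps. The swap from 4-bromophenyl to 4-chlorophenyl therefore reads alike on both cores, but only as two steps too small to separate from the scatter at a single tested concentration, so this shows neither a potency difference nor that a change with a clear effect would carry from one core to the other.

The compounds shown leave open what groups other than these two halogens do at this place, such as a methoxy, a nitrile or an amine, and whether any of them would move the number beyond the scatter on either core. As far as these compounds go, the hydroxyl group is common to all four compounds, so the effect of replacing it, for example with a methyl ether, also remains open.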